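The compounds below may be only part of what the source reports. "The series", "measured", "known", "first", "only" and "open" are said of these compounds alone.

Compounds measured so far:
compound 1 `Cc1cccc(-c2noc([C@H](C)NC(=O)c3cc(C4CC4)nn3C)n2)c1` — 167 nM
compound 2 `Cc1cccc(-c2noc([C@H](C)NC(=O)c3cc(C4CC4)n(C)n3)n2)c1` — > 30000 nM
compound 3 `Cc1cc(-c2noc([C@H](C)NC(=O)c3cc(C(F)(F)F)nn3C)n2)ncn1` — 1410 nM

In an assay on T-REx-293 cells for inhibition of potassium channel subfamily T member 1 (Homo sapiens), read by patch clamp (on this read-out higher numbers stand for weaker inhibition and lower numbers for stronger inhibition), compound 1 gives 167 nM. Compound 2 reaches only the limit of the assay, > 30000 nM, and no number is known for it; this is the limit noted in the limit of > 30000 nM in this assay, at which 1 of the 3 values shown sits. Compound 3 gives 1410 nM in this assay, the highest number among the two compounds with a number, and the gap to compound 1 lies beyond the usual scatter. Compound 4 `CNc1cc(-c2noc([C@H](C)NC(=O)c3cc(C(F)(F)F)nn3C)n2)ccn1` has not been measured in this assay. It differs from compound 3 in one place: 2-(methylamino)pyridin-4-yl in place of 6-methylpyrimidin-4-yl on an aromatic carbon. Within the data shown here, no measured pair shows a change of this kind, so the direction of the step is open. The author expects the number for compound 4 to stay close to that of compound 3, with any step in this assay likely no larger than the scatter, a 1.1-fold higher number from compound 3 to compound 4 (0.03 log units; within the scatter). Compound 4 is therefore estimated at 1500 nM, with a range from 400 nM to 6000 nM.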

Compound 4, half-maximal inhibitory concentration: 195 nM
Compound 4: middle estimate off by 7.7-fold (0.89 log units), on the high side; the whole stated range lies above it.
By their numbers in this assay, from the lowest: compounds 1 and 4 (each within the scatter of the next); then compound 3. At a limit, above all of these: compound 2.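

In this assay, putting 2-(methylamino)pyridin-4-yl in place of 6-methylpyrimidin-4-yl, on the aromatic carbon between two ring nitrogen atoms, gives a 7.2-fold lower number from compound 3 to compound 4 (0.86 log units; beyond the scatter) with the rest of the molecule unchanged. Among these compounds, this is the first comparison here of compounds that differ in one place, and it shows that this position responds to the ring it carries; the entering group has a hydrogen-bond donor that the leaving group lacks and fewer ring hetero atoms, and one step cannot separate these differences. Nothing measured here accounts for the step.

The compounds shown leave open whether 2-(dimethylamino)pyridin-4-yl or 2-methoxypyridin-4-yl would keep this gain. They also leave open whether the same change would act alike with cyclopropyl in place of trifluoromethyl.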